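The compounds below may be only part of what the source reports. "The series", "measured", "known", "first", "only" and "open" are said of these compounds alone.

Going by the values given here, compound 3 `C/N=C(\S)NCCCCn1nc(-c2ccccc2)ccc1=O` is the one member of this small set with a measured number: in a functional assay on the whole organism (stomach) with Rattus norvegicus as the target (a higher number here means that more compound is needed for the effect, a lower number that less compound is needed), compound 3 gives 28.9 mg/kg. Compound 2 `C/N=C(/NC#N)NCCCCn1nc(-c2ccccc2)c(C)cc1=O` shares the chain but carries a different core, and the difference between the two cores is not broken down here. In this assay compound 2 reaches only a limit of the assay, > 100 mg/kg. Compound 1 `CC/N=C(/NC#N)NCCCCn1nc(-c2ccccc2)c(C)cc1=O` differs from compound 2 by methyl in place of hydrogen on a saturated chain carbon bound to a double-bonded nitrogen. For compound 1 too, this assay reports a limit, > 100 mg/kg. Because compounds 1 and 2 both sit at the limit of > 100 mg/kg in this assay, at which 2 of the 3 values shown sit, the size of a step that the two limits leave unreadable from compound 2 to compound 1 cannot be read. Compound 4 `CC/N=C(\S)NCCCCn1nc(-c2ccccc2)ccc1=O` is not yet measured; it differs from compound 3 by methyl in place of hydrogen on a saturated chain carbon bound to a double-bonded nitrogen, the same change as that from compound 2 to compound 1. The measured pair gives no size for this change, so the expectation rests on compound 3 alone, whose value of 28.9 mg/kg is taken as the starting point. Compound 4 is expected to give about 30 mg/kg in this assay, most likely between 12 mg/kg and 80 mg/kg. This corresponds to an expected step of a 1.0-fold higher number from compound 3 to compound 4 (0.02 log units; within the scatter).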

Compound 4, dose for half-maximal effect: 37.2 mg/kg
Estimate against measurement, compound 4: 1.2-fold (0.09 log units) below; the measured number falls inside the stated range.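

In this assay, on the core of compound 3, methyl in place of hydrogen on a saturated chain carbon bound to a double-bonded nitrogen gives a 1.3-fold higher number from compound 3 to compound 4 (0.11 log units; within the scatter), so on this core the change cannot be told apart from the usual scatter of repeated measurements. On the other core the same change cannot be read, because compound 2 and compound 1 each give a limit of the assay rather than a number: the limit of > 100 mg/kg in this assay, at which 2 of the 4 values shown sit. The new step therefore describes the change on one core only, and it does not show that the change would behave alike on the core of compounds 1 and 2.

The compounds shown carry only methyl and ethyl at this place, so it remains open how a longer chain such as propyl, or a chain ending in a carboxylic acid, would read in this assay. Also open, from the compounds shown here alone, is whether any change at this place would bring the core of compound 1 to a readable number.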